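The source may report more compounds than this note shows. Statements on the series, on what has been measured and on what is new or still open speak of the compounds shown alone.

Within the data shown here, compound 2 `COc1ccc(-c2cc(=O)c3c(OC)cc(OC)cc3n2S(=O)(=O)c2ccc(C#N)cc2)cc1` is one of only two compounds measured so far in a functional assay on HepG2 cells (Homo sapiens) for antiproliferative activity, with a stated time of 72 h; on this read-out higher numbers stand for an effect only at larger amounts of compound and lower numbers for an effect already at smaller amounts. In this assay compound 2 gives only a limit, > 17200 nM, and no number. Compound 1 `COc1ccc(-c2cc(=O)c3c(OC)cc(OC)cc3n2Cc2ccccc2)cc1` likewise gives only a limit in this assay, > 17300 nM. Among the measured compounds shown here, the single measured step, a step that the two limits leave unreadable from compound 1 to compound 2, cannot be read because both of its ends sit at limits (the limit of > 17200 nM in this assay, at which 1 of the 2 values shown sits, and (the limit of > 17300 nM in this assay, at which 1 of the 2 values shown sits)). Compound 3 `COc1ccc(-c2cc(=O)c3c(OC)cc(OC)cc3n2S(=O)(=O)c2ccc(F)cc2)cc1` differs from compound 2 by fluoro in place of cyano on an aromatic carbon. For the measured compounds named here, no measured step bears on this change, and the one step known, benzyl to (4-cyanophenyl)sulfonyl on the aromatic nitrogen, has no readable size, so nothing can be carried over from it. Compound 3 is therefore expected to sit at a limit of this assay as well, which amounts to an expected step that the limit leaves unreadable from compound 2 to compound 3. For compound 3 the estimate is 20000 nM, with a range from 5000 nM to 80000 nM.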

Compound 3, half-maximal effective concentration: > 65500 nM
Compound 3 ended at the assay's limit (the forecaster's own chance of this, stated with the estimate: 80%); middle value at least 3.2-fold (0.51 log units) away from the limit.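

Among these compounds, compound 1, compound 2 and compound 3 all end at limits in this assay and give no numbers, so no step among them can be read. The compounds shown leave open at what concentration any of them acts, and whether fluoro in place of cyano makes any difference.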